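The source may hold more compounds than are shown below. What is called first, only, known or untested is meant among the compounds shown, and "the series" means these compounds.

Measured compounds:
compound 1, `CC[C@H](C)[C@H](NC(=O)c1cccc(Cn2ccnc2)c1)C(=O)Nc1nccs1`, 4%
compound 2, `CCCCS(=O)(=O)NNC(=O)[C@@H](NC(=O)c1cccc(Cn2ccnc2)c1)[C@@H](C)CC`, "not determined" (no result reported)
compound 3, `CCCCS(=O)(=O)NC(=O)[C@@H](NC(=O)c1cccc(Cn2ccnc2)c1)[C@@H](C)CC`, "not determined" (no result reported)

The three compounds share one core and differ in the group on the amide-type nitrogen. In an assay on HEK293 cells for displacement of a labelled ligand from Type-2 angiotensin II receptor (Homo sapiens), tested at 1 uM (on this read-out lower numbers stand for a weaker effect and higher numbers for a stronger effect at the one concentration tested), compound 1 gives 4%, a weak effect at the single concentration tested. Compound 2 and compound 3 have no number in this assay at all, so compound 3 stands without a measured position; the only anchor in the series is compound 1. Compound 4, `CC[C@H](C)[C@H](NC(=O)c1cccc(Cn2ccnc2)c1)C(=O)NNS(=O)(=O)c1ccccc1`, is the next step from compound 3. The change is (phenylsulfonyl)amino in place of butylsulfonyl on an amide-type nitrogen. Among the measured compounds shown here, nothing measured on compound 3 allows a step to be stated, and with compound 1 as the only read value, the writer expects the step from compound 3 to compound 4 in this assay to stay within the usual scatter, with no clear direction. Compound 4 is therefore estimated to give 8% in this assay, with a range from 0% to 25%.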

Compound 4, a percentage reported as inhibition, at one concentration (the size of the read-out at that concentration, not a potency): 6%
Estimate against measurement, compound 4: 2 percentage points above; measured number inside the range.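

With compound 4, the series gains its first readable comparison at this position: in this assay, placing (phenylsulfonyl)amino on the amide-type nitrogen in place of 1,3-thiazol-2-yl gives a number 2 percentage points higher from compound 1 to compound 4 (within the scatter), so these two very different groups read alike at the one concentration tested. The steps that involve compound 2 or compound 3 cannot be read, which leaves the exchange of butylsulfonyl for (phenylsulfonyl)amino without a measured comparison. No supporting data bear on why the two groups read alike.

From the compounds shown here alone, whether an amine, a carboxylic acid or a longer chain on this nitrogen would shift the read-out in this assay remains open. So does whether any change elsewhere on the shared core would do so.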